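The source may hold more compounds than are shown below. What is called first, only, known or untested is meant among the compounds shown, and "the series" means these compounds.

Measured so far in a physicochemical assay for solubility, read by HPLC, using the shake flask method, measured as kinetic solubility, with a stated time of 20 h, at pH 6.5, tested at 200 uM; a lower number here means a less soluble compound, a higher number a more soluble compound:
- Compound 1 `O=S(=O)(CCO)c1cccc(-c2ccc3nccc(-c4ccncc4)c3n2)c1`: 55000 nM
- Compound 2 `NS(=O)(=O)c1cncc(-c2ccc3nccc(-c4cn[nH]c4)c3n2)c1`: < 5000 nM

Among the compounds with values here, compound 1 holds the only true number here, 55000 nM. Compound 2 gives only a limit of the assay, < 5000 nM, and not a number. Within the data shown here, that leaves no measured step to serve as a guide.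

Compound 3 `CS(=O)(=O)Nc1cccc(-c2ccc3nccc(-c4ccncc4)c3n2)c1` keeps the core of compound 1 but has methanesulfonamido in place of (2-hydroxyethyl)sulfonyl on an aromatic carbon. Among the measured compounds shown here, no measured pair shows this exchange, so any forecast for this assay is uncertain. A moderate fall, somewhat beyond the usual scatter, is the expectation. The expected change is a 2.8-fold lower number from compound 1 to compound 3 (0.44 log units; beyond the scatter). For compound 3 the estimated value is 20000 nM, with an expected range from 5000 nM to 80000 nM.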

Compound 3, solubility: 20000 nM
Beside the measured number, compound 3's estimate shows no gap at the digits printed, and the stated range covers the measured number.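

In this assay, within the data shown here, this is the first measured exchange at this place, on an aromatic carbon of a six-membered aromatic ring of carbon only, and methanesulfonamido in place of (2-hydroxyethyl)sulfonyl gives a 2.8-fold lower number from compound 1 to compound 3 (0.44 log units; beyond the scatter). The rest of the molecule stays the same, and both groups count one hydrogen-bond donor and no ring, so sharing those counts does not keep the number in place. Compound 2 remains a limit and not a number, so it adds no step: the limit of < 5000 nM in this assay, at which 1 of the 3 values shown sits.

A single exchange cannot separate the parts of the change, such as losing the hydroxyl end of the chain or gaining the sulfonamide nitrogen. On these data alone, it remains open where an amine, a carboxylic acid or a longer chain at this same place would fall, and whether this step would hold with other changes to the shared core.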